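Adding a Chlorine Beside a Trifluoromethyl Group

This account rests on a few compounds, and the source may have more. Where it says the series, first, only, none or still open, it means among the compounds named here.

Of the compounds shown here, three sharing one core have been tested in a functional assay on HT-29 cells (Homo sapiens) for inhibition, read by sulforhodamine B assay, with a stated time of 48 h, tested at 10 uM; a higher number here means a weaker effect of the compound at the concentration tested, a lower number a stronger effect. Compound 1 `COc1cc2cc(Oc3ccc(NC(=O)Nc4ccccc4)cc3)c(C)nc2cc1OC` gives 48.9%. Compound 2 `COc1cc2cc(Oc3ccc(NC(=O)Nc4ccc(C)cc4)cc3)c(C)nc2cc1OC`, carrying a methyl on the outer ring, gives 115%. Compound 3 `COc1cc2cc(Oc3ccc(NC(=O)Nc4ccc(C(F)(F)F)cc4)cc3)c(C)nc2cc1OC`, with a trifluoromethyl there instead, gives 44.6%. For the measured compounds named here, compound 3 therefore stands at the low end of the numbers so far: from compound 1 the change is a number 4.3 percentage points lower from compound 1 to compound 3 (within the scatter), so these two are not separated, while from compound 2 the change is a number 70.4 percentage points lower from compound 2 to compound 3 (beyond the scatter), a clear separation.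

Compound 4 `COc1cc2cc(Oc3ccc(NC(=O)Nc4ccc(Cl)c(C(F)(F)F)c4)cc3)c(C)nc2cc1OC` differs from compound 3 only in the group on the amide-type nitrogen: 4-chloro-3-(trifluoromethyl)phenyl in place of 4-(trifluoromethyl)phenyl on an amide-type nitrogen. Going by the values given here, no measured step tests the addition of a chlorine; the two steps that touch this ring, a number 66.1 percentage points higher from compound 1 to compound 2 (beyond the scatter) and a number 4.3 percentage points lower from compound 1 to compound 3 (within the scatter), show that swapping one small group for another can move the read-out a lot or hardly at all. Since the trifluoromethyl of compound 3 is kept and only a chlorine is added, the step is expected to stay within the scatter, a number 4.6 percentage points lower from compound 3 to compound 4 (within the scatter). Compound 4 is thus estimated at 40%, within a range of 20% to 75%.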

Compound 4, a percentage reported as activity, at one concentration (the size of the read-out at that concentration, not a potency): -24.9%
Beside the measured number, compound 4's estimate is 64.9 percentage points above it; the whole stated range lies above it.
By their numbers in this assay, from the lowest: compound 4; then compounds 3 and 1 (each within the scatter of the next); then compound 2.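

In this assay the 4-chloro-3-(trifluoromethyl)phenyl group on the amide-type nitrogen gives the first large move towards a stronger effect at this place, with a number 69.5 percentage points lower from compound 3 to compound 4 (beyond the scatter) and a number 73.8 percentage points lower from compound 1 to compound 4 (beyond the scatter) as well as a number 139.9 percentage points lower from compound 2 to compound 4 (beyond the scatter) setting compound 4 clearly apart from all three earlier compounds. For the compounds shown here, until now the only large steps here involved the methyl of compound 2, on the weaker side, while the phenyl of compound 1 and the 4-(trifluoromethyl)phenyl of compound 3 could not be separated, so this place can now be seen to move the read-out far in both directions, with compound 4 at -24.9% even reaching a negative number. The change is also more than an added chlorine, since the two group names give the trifluoromethyl different numbers, and nothing at hand explains the size of the step.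

The compounds shown leave open whether the chlorine or the new place of the trifluoromethyl carries the step, which 4-chlorophenyl and 3-(trifluoromethyl)phenyl on the same nitrogen could separate. They also leave open how a methoxy, a nitrile or an amine on this ring would read.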